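Swapping fluoro for chloro on the shared core

The source may hold more compounds than are shown below. What is called first, only, known or untested is meant among the compounds shown, and "the series" means these compounds.

Three compounds built on one shared core were tested in a functional assay on COLO 205 cells (Homo sapiens) for inhibition, read by sulforhodamine B assay, with a stated time of 48 h, tested at 50 uM; on this read-out lower numbers stand for less inhibition of growth and higher numbers for more inhibition of growth at the one concentration tested. Compound 1 `O=C1C(=O)N(CCCCn2cc(COc3cc(=O)oc4ccccc34)nn2)c2ccc(F)cc21` gives 64%, the highest of the three numbers, though compound 3 `O=C1C(=O)N(CCCCCn2cc(COc3cc(=O)oc4ccccc34)nn2)c2ccccc21` gives 62%, which lies within the scatter of compound 1. Compound 2 `O=C1C(=O)N(CCCCCn2cc(COc3cc(=O)oc4ccccc34)nn2)c2ccc(Br)cc21` gives 39%, a number beyond the scatter below compound 1. Among the measured compounds shown here, the only step between measured compounds that differ in one place is a number 23 percentage points higher from compound 2 to compound 3 (beyond the scatter), hydrogen in place of bromo on an aromatic carbon.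

Compound 4 `O=C1C(=O)N(CCCCn2cc(COc3cc(=O)oc4ccccc34)nn2)c2ccc(Cl)cc21` has not yet been measured. It differs from compound 1 by chloro in place of fluoro on an aromatic carbon. For the measured compounds named here, no measured step exchanges one halogen for another, so the step from compound 2 to compound 3 bears on it only loosely: there the bromo compound gave the lower number, while compound 1 with fluoro sits high. A step of at most modest size, more likely downward than upward, is expected, a number 9 percentage points lower from compound 1 to compound 4 (within the scatter). Compound 4 is therefore estimated at 55%, with a range from 35% to 72%.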

Compound 4, percent growth inhibition at one concentration: 60%
Beside the measured number, compound 4's estimate is 5 percentage points below it; low and high end bracket the measured number.
By their numbers in this assay, from the lowest: compound 2; then compounds 4, 3 and 1 (each within the scatter of the next).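

In this assay, the exchange of one halogen for another on the shared core gives a number 4 percentage points lower from compound 1 to compound 4 (within the scatter), so this step lies within the scatter. On the chain of compound 1, this aromatic carbon therefore carries either fluoro or chloro with no readable change in growth inhibition at the one concentration tested, something the earlier step could not show, as it replaced bromo with hydrogen on a different chain. No measurement at hand offers an explanation for this result.

Open, on these data alone, is how an amine, a methoxy group or a carboxylic acid on this aromatic carbon would read. Also open, as far as these compounds go, is whether the chloro compound would hold its number if the chain of compound 1 gave way to the chain of compound 3.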